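The source may report more compounds than this note shows. Statements on the series, on what has been measured and on what is new or still open speak of the compounds shown alone.

Compound 2 `O=[N+]([O-])c1cn2c(n1)OC[C@@H](NCc1ccc(OC(F)(F)F)c(O)c1)C2` has the higher of the two solubility numbers recorded here. In a physicochemical assay for solubility, at pH 6.8 (on this read-out higher numbers stand for higher solubility and lower numbers for lower solubility), compound 2 gives 56 ug/mL, while compound 1 `O=[N+]([O-])c1cn2c(n1)OC[C@@H](NCc1ccc(OC(F)(F)F)cc1Oc1ccccc1)C2` gives 3 ug/mL in this assay, a gap that lies beyond the usual scatter of this assay. The step under consideration leads to compound 3 `O=[N+]([O-])c1cn2c(n1)OC[C@@H](NCc1ccc(OC(F)(F)F)c(Cl)c1)C2`, which differs from compound 2 by chloro in place of hydroxy on an aromatic carbon, ortho to a trifluoromethoxy group and meta to a large group. Among the measured compounds shown here, no measured pair in this set shows exactly this exchange, so the size of its effect in this assay can only be estimated. The solubility of compound 3 in this assay is expected to fall clearly below that of compound 2, with the step from compound 2 to compound 3 estimated at a 7.0-fold lower number from compound 2 to compound 3 (0.85 log units; beyond the scatter). On that basis compound 3 is expected to give about 8 ug/mL, with a likely range from 2 ug/mL to 30 ug/mL.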

Compound 3, solubility: 77 ug/mL
The estimate for compound 3 lay 9.6-fold (0.98 log units) below the measured number; measured number above the stated range.
By their numbers in this assay, from the lowest: compound 1; then compounds 2 and 3 (each within the scatter of the next).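

In this assay, chloro in place of hydroxy on an aromatic carbon, ortho to a trifluoromethoxy group and meta to a large group, gives a 1.4-fold higher number from compound 2 to compound 3 (0.14 log units; within the scatter), so the two groups cannot be told apart at this position on this read-out. Hydroxy brings a hydrogen-bond donor and a hydrogen-bond acceptor and chloro neither, yet this one pair shows no separation between compound 2 and compound 3. Nothing measured here accounts for this result.

Going by these compounds, whether a methoxy group, an amine or a carboxylic acid on this same carbon would also read level with compound 2 remains open. Also open, on these data alone, is whether the same exchange would give a step of this size in a compound carrying the phenoxy group of compound 1.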